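This account rests on a few compounds, and the source may have more. Where it says the series, first, only, none or still open, it means among the compounds named here.

Compound 1 `Cc1ccc(CCCN(CC[C@H](N)C(=O)O)C[C@H]2O[C@@H](n3cnc4c(N)ncnc43)[C@H](O)[C@@H]2O)cc1C(N)=O` sets the reference point: in an assay on cells for inhibition of Nicotinamide N-methyltransferase (Homo sapiens), read by fluorescence and coupled enzyme assay, with a stated time of 10 min, in the presence of a further agent that is not named here (a higher number here means a weaker inhibitor, a lower number a stronger inhibitor), compound 1 gives 51 nM, the lowest of the three numbers in hand. Compound 3 `NC(=O)c1cccc(C#CCNC[C@H]2O[C@@H](n3cnc4c(N)ncnc43)[C@H](O)[C@@H]2O)c1` reaches 3000 nM in this assay, and compound 2 `Nc1ncnc2c1ncn2[C@@H]1O[C@H](CN(CCCc2ccc3ccccc3c2)CCC[C@H](N)C(=O)O)[C@@H](O)[C@H]1O` sits furthest off at 33300 nM; both gaps from compound 1 lie beyond the scatter.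

Compound 4 `NC(=O)c1cccc(CCCCN(CC[C@H](N)C(=O)O)C[C@H]2O[C@@H](n3cnc4c(N)ncnc43)[C@H](O)[C@@H]2O)c1` differs from compound 1 by a group of 10 heavy atoms (8 carbon, 1 nitrogen, 1 oxygen; one six-membered aromatic ring of carbon only) in place of a group of 10 heavy atoms (8 carbon, 1 nitrogen, 1 oxygen; one six-membered aromatic ring of carbon only), on a saturated chain carbon, three bonds along the chain from an amine nitrogen, so the carbamoyl-bearing ring is redrawn and the chain to it lengthened, with the total atom count unchanged.

Within the data shown here, no pair of measured compounds isolates this change. Since compound 3, which also carries a carbamoyl ring on a shorter, unsubstituted chain, gives 3000 nM, a loss of some size is expected from compound 1 to compound 4, a 5.9-fold higher number from compound 1 to compound 4 (0.77 log units; beyond the scatter). Compound 4 is estimated at 300 nM, in the range 80 nM to 1500 nM.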

Compound 4, inhibition constant: 840 nM
For compound 4 the middle estimate is 2.8-fold (0.45 log units) below the measured one, within the range that was stated.
By their numbers in this assay, from the lowest: compound 1; then compound 4; then compound 3; then compound 2.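

In this assay, placing the 3-carbamoylbenzyl group on a saturated chain carbon, three bonds along the chain from an amine nitrogen, in place of the isomeric group of compound 1 gives a 16-fold higher number from compound 1 to compound 4 (1.22 log units; beyond the scatter). At this position, the same atoms joined differently are enough for a step beyond the scatter, so composition alone does not set the value. Nothing measured here bears on the reason for this step.

From the compounds shown here alone, whether the ring methyl or the chain length carries the step remains open, as does the outcome with a nitrile or a carboxylic acid in place of the carbamoyl group.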